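Cyclising the amidine side chain in a cytotoxicity series

The source may hold more compounds than are shown below. What is called first, only, known or untested is meant among the compounds shown, and "the series" means these compounds.

Compound 1: `COc1ccc(CNC(=O)CC2c3ccccc3N=C(N(C)CCCCCN(C)C)N2c2ccc(-c3ccccc3)cc2)cc1` — 4460 nM
Compound 2: `CN(C)CCCCN(C)C1=Nc2ccccc2C(CC(=O)NCc2ccccc2)N1c1ccc(-c2ccccc2)cc1` — 9780 nM
Compound 3: `CN(C)CCCCCCN(C)C1=Nc2ccccc2C(CC(=O)NCc2ccccc2)N1c1ccc(-c2ccccc2)cc1` — 5780 nM

Of the compounds shown here, three sharing one core have been tested in a functional assay on SK-OV-3 cells (Homo sapiens) for cytotoxicity, read by MTT assay, with a stated time of 48 h; on this read-out lower numbers stand for stronger inhibition and higher numbers for weaker inhibition. Compound 3 gives the second highest of the three numbers; its nearest neighbour is compound 1, and its furthest is compound 2, yet both of those gaps fall within the scatter, so no order among the three can be claimed.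

The next compound, compound 4 `CN(C)CCN1CCN(C2=Nc3ccccc3C(CC(=O)NCc3ccccc3)N2c2ccc(-c3ccccc3)cc2)CC1`, is reached from compound 3 through the change (4-(2-(dimethylamino)ethyl)piperazin-1-yl in place of (6-(dimethylamino)hexyl)(methyl)amino on a carbon with a double bond to nitrogen). Among the measured compounds shown here, this is a different kind of alteration from the one measured step in the set: in a 1.7-fold lower number from compound 2 to compound 3 (0.23 log units; within the scatter) only the length of the open chain grew, and the number moved within the scatter. For the measured compounds named here, nothing measured so far speaks to closing the side chain into a ring at this position, so that step can only indicate that small variations of this amine tail have left this assay largely unmoved.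

On that basis compound 4 is expected to remain close to compound 3, with a 1.0-fold higher number from compound 3 to compound 4 (0.02 log units; within the scatter), the estimate being 6000 nM and the plausible range running from 2500 nM to 15000 nM.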

Compound 4, half-maximal inhibitory concentration: 1970 nM
Estimate against measurement, compound 4: 3.0-fold (0.48 log units) above; measured number outside the range, below it.
By their numbers in this assay, from the lowest: compound 4; then compounds 1, 3 and 2 (each within the scatter of the next, the first and the last beyond it).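

In this assay, this position proves sensitive to the form of the amine tail, not only to its length: putting 4-(2-(dimethylamino)ethyl)piperazin-1-yl in place of the open chain gives a 2.9-fold lower number from compound 3 to compound 4 (0.47 log units; beyond the scatter), and against the shorter chain it gives a 5.0-fold lower number from compound 2 to compound 4 (0.70 log units; beyond the scatter). Lengthening the open chain had given only a 1.7-fold lower number from compound 2 to compound 3 (0.23 log units; within the scatter), so these modest steps are the first in the set to pass beyond the scatter. The entering group has the same heavy-atom count as the (6-(dimethylamino)hexyl)(methyl)amino group it replaces, but it brings a six-membered non-aromatic ring and one carbon is exchanged for a nitrogen, so the step from compound 3 shows that a rearrangement of the tail at equal heavy-atom count is enough to move the number.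

The compounds shown do not separate the ring from the added nitrogen, a question that a 4-(2-(dimethylamino)ethyl)piperidin-1-yl or a simple 4-methylpiperazin-1-yl group at this carbon would bear on. No evidence accompanies these values to explain the shift.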